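Restoring a methyl on the amide-side chain of a lipopeptide

A few compounds are considered here, and "the series" means these few. Any claim that something is new, unique, unknown or untested is made for them only; others in the source may bear on it.

Compound 2, `CCCCCCCCCCCC(=O)OC[C@H](CSC[C@@H](N)C(=O)NCCO)OC(=O)CCCCCCCCCCC`, gives 24 nM in an assay on HEK293 cells for agonist activity at Toll-like receptor 2 (Homo sapiens); a lower number here means that less compound is needed, a higher number that more compound is needed for the effect. Among the two compounds measured so far it carries the lowest number; the nearest is compound 1, `CCCCCCCCCCCC(=O)OC[C@H](CSC[C@@H](N)C(=O)N[C@@H](C)CO)OC(=O)CCCCCCCCCCC`, which gives 1560 nM in this assay. The step from compound 1 to compound 2 was a 65-fold lower number from compound 1 to compound 2 (1.81 log units; beyond the scatter).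

Compound 3, `CCCCCCCCCCCC(=O)OC[C@H](CSC[C@@H](N)C(=O)N[C@H](C)CO)OC(=O)CCCCCCCCCCC`, is the unmeasured compound. The change from compound 2 to compound 3 is methyl in place of hydrogen on a saturated chain carbon bound to an amide-type nitrogen and a saturated chain carbon. This is the same kind of group, placed on the same chain carbon, that was taken away in the step from compound 1 to compound 2, although compound 3 is not identical to compound 1. Since that removal gave a large drop, putting a methyl back is expected to raise the number again, although how far the earlier step carries over is uncertain. For compound 3 the expected step is a 21-fold higher number from compound 2 to compound 3 (1.32 log units; beyond the scatter), so a value of about 500 nM is estimated, within a range from 60 nM to 3000 nM.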

Compound 3, half-maximal effective concentration: 22200 nM
The estimate for compound 3 lay 44-fold (1.65 log units) below the measured number, and the stated range ends below it.
By their numbers in this assay, from the lowest: compound 2; then compound 1; then compound 3.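

In this assay, a methyl on the saturated chain carbon bound to the amide-type nitrogen raises the number in either drawn configuration, and the new form does so most sharply, with a 930-fold higher number from compound 2 to compound 3 (2.97 log units; beyond the scatter). So the earlier drop did not simply measure the presence or absence of a methyl: which way the methyl is drawn also counts. The two methyl compounds are separated by a 14-fold higher number from compound 1 to compound 3 (1.15 log units; beyond the scatter), and this gap can be traced to the stereocentre alone because of one fact: the fact that compounds 1 and 3 differ only in the configuration as drawn

As far as these compounds go, what remains open is whether an ethyl group on the same carbon would follow the same order between its two configurations. From the compounds shown here alone, it is also open whether an amine in place of the hydroxyl of the 2-hydroxyethyl chain would keep the low number of compound 2.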